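Swapping one side group on compound 1

This account rests on a few compounds, and the source may have more. Where it says the series, first, only, none or still open, it means among the compounds named here.

In a functional assay on MDA-MB-231 cells (Homo sapiens) for cytotoxicity, read by MTT assay, with a stated time of 96 h (a higher number here means a weaker inhibitor, a lower number a stronger inhibitor), compound 1 (`CC[C@H](N)C(=O)N[C@@H]1C(=O)N2[C@@H](CC[C@@H]1CNC(=O)NCc1ccccc1)CC[C@H]2C(=O)NC(c1ccccc1)c1ccccc1`) gives 3400 nM as the highest of three measured numbers. Compound 2 (`CC[C@H](N)C(=O)N[C@@H]1C(=O)N2[C@@H](CC[C@@H]1CCO)CC[C@H]2C(=O)NC(c1ccccc1)c1ccccc1`) gives 1800 nM and stays within the scatter of compound 1, while compound 3 (`CC[C@H](NC)C(=O)N[C@@H]1C(=O)N2[C@@H](CC[C@@H]1CCNC(=O)NCc1ccccc1)CC[C@H]2C(=O)NC(c1ccccc1)c1ccccc1`) gives 1200 nM and lies lower than compound 1 by more than the scatter.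

The unmeasured compound 4 (`CCNCC[C@H]1CC[C@H]2CC[C@@H](C(=O)NC(c3ccccc3)c3ccccc3)N2C(=O)[C@H]1NC(=O)[C@@H](N)CC`) keeps the core of compound 1 and changes one group. The change reads (ethylamino)methyl in place of (benzylcarbamoyl)amino on a saturated chain carbon bound to a saturated ring carbon and amounts to (ethylamino)methyl in place of (benzylcarbamoyl)amino on a saturated chain carbon bound to a saturated ring carbon.

Among the compounds with values here, one measured step bears on this, since the same group also leaves when hydroxymethyl enters: a 1.9-fold lower number from compound 1 to compound 2 (0.28 log units; within the scatter) and that step stays within the scatter. Within the data shown here, no single-place step joins compound 3 to compound 1, so its value gives no size for this change. Among the measured compounds shown here, no measured compound carries (ethylamino)methyl itself, which leaves the step from compound 1 to compound 2 as the only guide. The expected step is a 1.7-fold lower number from compound 1 to compound 4 (0.23 log units; within the scatter) and it is expected to be no larger than the scatter, with any shift towards a lower number. For compound 4 the estimate is 2000 nM with 700 nM to 6000 nM as the expected range.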

Compound 4, half-maximal inhibitory concentration: 8000 nM
For compound 4 the middle estimate is 4.0-fold (0.60 log units) below the measured one, and the stated range ends below it.
By their numbers in this assay, from the lowest: compounds 3, 2 and 1 (each within the scatter of the next, the first and the last beyond it); then compound 4.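

In this assay the position proves able to move the number beyond the scatter: the step to (ethylamino)methyl on a saturated chain carbon bound to a saturated ring carbon is a 2.4-fold higher number from compound 1 to compound 4 (0.37 log units; beyond the scatter) and runs upward, so losing (benzylcarbamoyl)amino does not by itself settle the outcome. With the chain otherwise unchanged, ethylamino in place of hydroxy gives a 4.4-fold higher number from compound 2 to compound 4 (0.65 log units; beyond the scatter) and also lies beyond the scatter, which shows that the two smaller groups entering here are not interchangeable, although neither carries the aromatic ring of the group that leaves. Nothing given here explains either step.

The compounds shown leave open whether the higher number of compound 4 goes with the nitrogen at the end of this chain or with its ethyl group, a question that a primary amine or a methoxy group in the same place would help to answer. On these data alone, how a carboxylic acid or a longer chain carrying ethylamino would read at this position also remains open.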